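Solubility notes: amide series, compound 3 to compound 4

This account rests on a few compounds, and the source may have more. Where it says the series, first, only, none or still open, it means among the compounds named here.

Measured so far in a physicochemical assay for solubility, read by spectrophotometry, measured as kinetic solubility, at pH 8, tested at 500 uM; on this read-out higher numbers stand for higher solubility and lower numbers for lower solubility:
- compound 1 `CN1CCC(CNS(=O)(=O)c2ccccc2Nc2cc(-c3ccc4ccn(C)c4c3)c3nccnc3c2)C1`: 35 ug/mL
- compound 2 `CN(Cc1cncnc1)S(=O)(=O)c1ccccc1Nc1cc(-c2ccc3ccn(C)c3c2)c2nccnc2c1`: 3 ug/mL
- compound 3 `Cn1ccc2ccc(-c3cc(Nc4cnccc4C(=O)NCc4cncnc4)cc4nccnc34)cc21`: 233 ug/mL

Compound 3 gives the highest number of the three, with compound 1 nearest and compound 2 furthest; both gaps lie beyond the scatter. The number for compound 3 already approaches the amount that the test concentration allows, so there is little room upward.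

Compound 4 `CC(=O)N1CCC(NC(=O)c2ccncc2Nc2cc(-c3ccc4ccn(C)c4c3)c3nccnc3c2)C1` differs from compound 3 as follows: 1-acetylpyrrolidin-3-yl in place of (pyrimidin-5-yl)methyl on an amide-type nitrogen.

Going by the values given here, only one measured step exists, and it sits elsewhere, on a sulfonyl sulfur in the sulfonamide pair: a 12-fold lower number from compound 1 to compound 2 (1.07 log units; beyond the scatter). There the (pyrimidin-5-yl)methyl group entered and the number fell. Among the compounds with values here, in the present step the same group leaves, so if the analogy carries, the number should not fall; the entering 1-acetylpyrrolidin-3-yl group has no measured precedent here. Compound 3 gives 233 ug/mL. Starting from that number, the expected step is a 1.2-fold lower number from compound 3 to compound 4 (0.07 log units; within the scatter), none beyond the scatter. Compound 4 is therefore estimated at 200 ug/mL, range 90 ug/mL to 250 ug/mL.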

Compound 4, solubility: 253 ug/mL
The estimate for compound 4 lay 1.3-fold (0.10 log units) below the measured number; measured number above the stated range.
By their numbers in this assay, from the lowest: compound 2; then compound 1; then compounds 3 and 4 (each within the scatter of the next).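

In this assay, 1-acetylpyrrolidin-3-yl in place of (pyrimidin-5-yl)methyl on the amide-type nitrogen gives a 1.1-fold higher number from compound 3 to compound 4 (0.04 log units; within the scatter) and so a five-membered non-aromatic ring and a six-membered aromatic ring read alike at this place. The (pyrimidin-5-yl)methyl group is thus not required for a high number in this amide pair, whereas on a sulfonyl sulfur, against a different partner, the same group entered with a 12-fold lower number from compound 1 to compound 2 (1.07 log units; beyond the scatter) and a large step. No measurement on hand gives a reason for either result.

As far as these compounds go, it remains open how close compound 3 and compound 4 sit to the upper end that the test concentration allows. Also open, from the compounds shown here alone, is whether a carboxylic acid or a simple alkyl amine on the amide-type nitrogen would give a step beyond the scatter.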